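A few compounds are considered here, and "the series" means these few. Any claim that something is new, unique, unknown or untested is made for them only; others in the source may bear on it.

Compound 1 `C/C=C1\C=C(C)C2(CC2)C(C)(O)C1=O` gives 120 nM in a functional assay on SW480 cells (Homo sapiens) for antiproliferative activity (a higher number here means a weaker inhibitor, a lower number a stronger inhibitor), the lowest number among the three measured compounds. Compound 2 `CC1=C/C(=C\c2ccccc2)C(=O)C(C)(O)C12CC2` gives 2500 nM and compound 3 `CC1=C/C(=C\C#CCCO)C(=O)C(C)(O)C12CC2` gives 4000 nM. The unmeasured compound 4 `C=C/C=C1\C=C(C)C2(CC2)C(C)(O)C1=O` differs from compound 1 by vinyl in place of methyl on a double-bonded chain carbon bound to a double-bonded ring carbon. Going by the values given here, two measured steps bear on this change, both replacing the same methyl with a larger group: a 21-fold higher number from compound 1 to compound 2 (1.32 log units; beyond the scatter) and a 33-fold higher number from compound 1 to compound 3 (1.52 log units; beyond the scatter). Both point toward weaker inhibition in this assay when this methyl is exchanged, though neither step concerns vinyl itself. Compound 4 is therefore expected to be a weaker inhibitor than compound 1, by a step smaller than those two, estimated as a 3.8-fold higher number from compound 1 to compound 4 (0.57 log units; beyond the scatter). Compound 4 is expected to give about 450 nM in this assay, within a range of 150 nM to 1500 nM.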

Compound 4, half-maximal inhibitory concentration: 180 nM
Estimate against measurement, compound 4: 2.5-fold (0.40 log units) above; the measured number falls inside the stated range.
By their numbers in this assay, from the lowest: compounds 1 and 4 (each within the scatter of the next); then compounds 2 and 3 (each within the scatter of the next).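

In this assay the exchange of methyl for vinyl, seen as a 1.5-fold higher number from compound 1 to compound 4 (0.18 log units; within the scatter) and so within the scatter, shows that this place does not lose activity with every replacement of the methyl. Vinyl also stands well apart from the other two groups here, with a 22-fold lower number from compound 3 to compound 4 (1.35 log units; beyond the scatter) against 4-hydroxybut-1-yn-1-yl and a 14-fold lower number from compound 2 to compound 4 (1.14 log units; beyond the scatter) against phenyl. Nothing available accounts for this difference.

As far as these compounds go, it remains open whether ethyl, a longer chain or an amine in this place would group with compound 1 and compound 4 or with compound 2 and compound 3.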